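The compounds below may be only part of what the source reports. "The series", "measured", "known", "first", "only" and "open" are said of these compounds alone.

Measured values:
- compound 1, `Nc1scc(CN2CCN(c3ccc(Cl)c(C(F)(F)F)c3)CC2)c1C(=O)c1ccc(Cl)cc1`: -12%
- compound 2, `Nc1scc(CN2CCN(c3ccc(C(F)(F)F)cc3)CC2)c1C(=O)c1cccc(C(F)(F)F)c1`: -11%
- compound 3, `Nc1scc(CN2CCN(c3c(F)cccc3F)CC2)c1C(=O)c1cccc(C(F)(F)F)c1`: 1.3%

In a functional assay on CHO cells with adenosine receptor A1 (Homo sapiens) as the target, read by cAMP accumulation and immunoassay, with a stated time of 6 min, tested at 0.1 uM (a lower number here means a stronger effect, a higher number a weaker effect of the compound at the concentration tested), compound 1 stands lowest of the three numbers; its nearest neighbour is compound 2, within the scatter, and the furthest is compound 3, beyond it. Compound 4, `Nc1scc(CN2CCN(c3ccc(F)c(Cl)c3)CC2)c1C(=O)c1ccc(Cl)cc1`, has not been measured in this assay. It differs from compound 1 in one place: 3-chloro-4-fluorophenyl in place of 4-chloro-3-(trifluoromethyl)phenyl on an amine nitrogen in a ring. Among the measured compounds shown here, the only measured step that touches the same place is a number 12.3 percentage points higher from compound 2 to compound 3 (beyond the scatter), which swapped the aryl group on the ring nitrogen and moved the number upward by a modest amount. That step involved a different pair of aryl groups, so it bears on compound 4 only loosely; the change from compound 1 to compound 4 keeps a chlorine on the ring and exchanges the trifluoromethyl for a fluorine. The expectation is therefore a step of about a number 4 percentage points higher from compound 1 to compound 4 (within the scatter), most likely within the scatter. Compound 4 is estimated at -8%, with a range from -22% to 6%.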

Compound 4, a percentage reported as activity, at one concentration (the size of the read-out at that concentration, not a potency): -21%
Beside the measured number, compound 4's estimate is 13 percentage points above it; the measured number falls inside the stated range.
By their numbers in this assay, from the lowest: compounds 4, 1 and 2 (each within the scatter of the next); then compound 3.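

In this assay, replacing 4-chloro-3-(trifluoromethyl)phenyl with 3-chloro-4-fluorophenyl on the amine nitrogen in a ring gives a number 9 percentage points lower from compound 1 to compound 4 (within the scatter) and so shows that this position accepts an aryl group with fewer heavy atoms without a separation of the two numbers. Among the compounds shown here, the only earlier step at this position, a number 12.3 percentage points higher from compound 2 to compound 3 (beyond the scatter), did go beyond the scatter, so not every aryl exchange here leaves the read-out unresolved. Nothing available explains either outcome.

Whether the nitrogen needs an aryl group at all remains open, since a pyridyl ring, a benzyl group or a simple methyl does not appear among these compounds. The read-out at one concentration also leaves the potency of the compounds open.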